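The source may report more compounds than this note shows. Statements on the series, on what has been measured and on what is new or still open speak of the compounds shown alone.

Of the compounds shown here, three have been measured so far, all on the same shared core. Compound 1 `CC(C)n1nc(-c2cc(C(C)(C)C)on2)c2c(N)ncnc21` and compound 3 `CC(C)n1nc(-c2cc(-c3ccccc3)on2)c2c(N)ncnc21` carry the same group on the ring nitrogen and differ only at an aromatic carbon, where compound 3 has phenyl in place of tert-butyl. In an assay on BaF3 cells for inhibition of proto-oncogene tyrosine-protein kinase receptor Ret (Homo sapiens), read by MTT assay, with a stated time of 48 h (on this read-out lower numbers stand for stronger inhibition of growth and higher numbers for weaker inhibition of growth), compound 1 gives 6120 nM, and compound 3 gives 3460 nM. The step of a 1.8-fold lower number from compound 1 to compound 3 (0.25 log units; within the scatter) is the only measured one and lies within the scatter, so the two values are not told apart.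

Compound 2 `CCCCCCCn1nc(-c2cc(C3CC3)on2)c2c(N)ncnc21` carries heptyl on the ring nitrogen and a 5-cyclopropyl-1,2-oxazol-3-yl group. In this assay compound 2 gives > 10000 nM, which is a limit of the assay and not a number; it stands at the limit of > 10000 nM in this assay, at which 1 of the 3 values shown sits.

Compound 4 `Nc1ncnc2c1c(-c1cc(C3CC3)on1)nn2C1CCOCC1` differs from compound 2 in one place: oxan-4-yl in place of heptyl on an aromatic nitrogen. Going by the values given here, no measured step touches the group on the ring nitrogen, so the one measured step, at the aromatic carbon, gives no guide to its size. Since compound 2 sits at a limit, a number rather than a limit would itself appear as a step to a lower value; compound 4 is therefore expected to show an at least 2.0-fold lower number from compound 2 to compound 4 (0.30 log units; that floor lies within the scatter), landing near the range of compound 1 and compound 3. The estimate for compound 4 is 5000 nM, within 1500 nM to 15000 nM.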

Compound 4, concentration for 50% growth inhibition: 440 nM
Compound 4: middle estimate off by 11-fold (1.06 log units), on the high side; the measured number lies below the stated range.
By their numbers in this assay, from the lowest: compound 4; then compounds 3 and 1 (each within the scatter of the next). At a limit, above all of these: compound 2.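

In this assay, going by these compounds alone, the group on the aromatic nitrogen proves able to move the number: with the 5-cyclopropyl-1,2-oxazol-3-yl group unchanged, oxan-4-yl in place of heptyl gives an at least 22-fold lower number from compound 2 to compound 4 (1.35 log units; beyond the scatter) and so is the first step beyond the scatter. The only earlier step, at the aromatic carbon, stayed within the scatter, so this nitrogen is the one place shown so far where a single change separates two compounds. Compound 2 stands at a limit and not at a number, so this step has a floor but no known size: the limit of > 10000 nM in this assay, at which 1 of the 4 values shown sits.

The compounds shown do not tell whether the ring or its oxygen matters, which a cyclohexyl group or a piperidin-4-yl group at this nitrogen could help to separate. Within the data shown here, how far the step depends on the group on the other ring also stays open, as no pair shows this nitrogen change with phenyl or tert-butyl in place of cyclopropyl.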